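A few compounds are considered here, and "the series" means these few. Any claim that something is new, unique, unknown or untested is made for them only; others in the source may bear on it.

Measured so far in a functional assay on the whole organism for inhibition, with Mus musculus as the target, with a stated time of 1 h, at a dose of 30 mg/kg by the intraperitoneal route; on this read-out lower numbers stand for less inhibition and higher numbers for more inhibition at the one dose given (going by the name of the read-out):
- compound 1 `O=C(/C=C/C1=Cc2ccccc2OC1)c1ccc(F)cc1`: 65.6%
- compound 2 `O=C(/C=C/C1=Cc2ccccc2OC1)c1ccccc1Cl`: 52.3%
- compound 3 `CN(C)c1ccc(C(=O)/C=C/C2=Cc3ccccc3OC2)cc1`: 57.3%

Compound 2 stands lowest of the three numbers. Compound 3 lies nearest, a number within the scatter above it, and compound 1 lies furthest, a number beyond the scatter above it.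

Compound 4 `Nc1ccc(C(=O)/C=C/C2=Cc3ccccc3OC2)cc1` is not yet measured. It differs from compound 2 in one place: 4-aminophenyl in place of 2-chlorophenyl on a carbonyl carbon.

Within the data shown here, two measured steps bear on this. The step of a number 13.3 percentage points lower from compound 1 to compound 2 (beyond the scatter) exchanged 4-fluorophenyl for the same 2-chlorophenyl that now leaves; the step of a number 8.3 percentage points lower from compound 1 to compound 3 (within the scatter) put dimethylamino in place of fluoro on an aromatic carbon, a change of the same kind as the 4-aminophenyl that enters. Read together, a return from 2-chlorophenyl to a 4-substituted phenyl is expected to lift the number back toward those of compound 1 and compound 3, with the change in the substituent adding little beyond the scatter. The expected step is a number 5.7 percentage points higher from compound 2 to compound 4 (within the scatter), a modest rise. For compound 4 the estimate in this assay is 58%, within a range of 45% to 70%.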

Compound 4, a percentage reported as inhibition, in the whole organism at one dose (the size of the read-out at that dose, not a potency): 52.6%
Beside the measured number, compound 4's estimate is 5.4 percentage points above it, and the stated range covers the measured number.
By their numbers in this assay, from the lowest: compounds 2, 4, 3 and 1 (each within the scatter of the next, the first and the last beyond it).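

In this assay the exchange of 2-chlorophenyl for 4-aminophenyl on the carbonyl carbon gives a number 0.3 percentage points higher from compound 2 to compound 4 (within the scatter) and so does not bring the number back to that of compound 1. Amino in place of dimethylamino gives a number 4.7 percentage points lower from compound 3 to compound 4 (within the scatter) and leaves the two amines unseparated here, whereas amino in place of fluoro gives a number 13 percentage points lower from compound 1 to compound 4 (beyond the scatter) as a second step from compound 1 beyond the scatter, so among these 4-substituted phenyl groups the substituent itself can matter. No measured evidence offers an explanation for these numbers.

Open, going by these compounds, is whether 4-hydroxyphenyl or 4-methoxyphenyl would stand with compound 1 or with compound 4. Also open, on these data alone, is whether 4-chlorophenyl would stand with compound 1 or with compound 2, which would separate the chlorine from its place on the ring.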